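The compounds below may be only part of what the source reports. "The series", "measured", "known", "first", "only" and "open" are said of these compounds alone.

In a functional assay on NCI-H460 cells (Homo sapiens) for inhibition, read by sulforhodamine B assay, with a stated time of 48 h (a higher number here means a weaker inhibitor of growth, a lower number a stronger inhibitor of growth), the data so far are thin. For compound 1 (`Cc1cn([C@H]2C[C@H](CC3=CC(=O)C(=O)C=C3)[C@@H](CO[Si](C)(C)C(C)(C)C)O2)c(=O)[nH]c1=O`) the record reads no result reported, so it offers no comparison. Among the compounds with values here, compound 2 (`COc1ccc(C2([C@H]3C[C@H](n4cc(C)c(=O)[nH]c4=O)O[C@@H]3CO[Si](C)(C)C(C)(C)C)SCCCS2)cc1OC`) gives 3630 nM as the only number available, which leaves it without a rank: it can be called neither strong nor weak against its relatives. Compound 3 (`COc1ccc(C2([C@H]3C[C@@H](n4cc(C)c(=O)[nH]c4=O)O[C@@H]3CO[Si](C)(C)C(C)(C)C)SCCCS2)cc1OC`) has not yet been measured. It has the same atoms and bonds as compound 2 and differs only in configuration as drawn (the two compounds have the same atoms and bonds and differ only in configuration as drawn: 1 of 3 stereo elements differ; a stereocentre at a saturated ring carbon is drawn R in compound 2 and S in compound 3), with a stereocentre at a saturated ring carbon drawn R in compound 2 and S in compound 3. Within the data shown here, no measured pair here shows what such a change does, so neither direction is favoured, and no shift beyond the usual scatter is expected in this assay as the default. The estimated change is small (a 1.1-fold higher number from compound 2 to compound 3 (0.04 log units; within the scatter)) and carries wide uncertainty. That expectation rests only on compound 2 at 3630 nM as its anchor. For compound 3 the expected value is 4000 nM with an estimated range from 1500 nM to 12000 nM while the measurement is awaited.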

Compound 3, concentration for 50% growth inhibition: 5620 nM
The estimate for compound 3 lay 1.4-fold (0.15 log units) below the measured number, and the stated range covers the measured number.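

In this assay, the step reads a 1.5-fold higher number from compound 2 to compound 3 (0.19 log units; within the scatter), so taking this stereocentre at a saturated ring carbon from R to S as drawn leaves the two readings within the usual scatter of each other. Within the data shown here, until now the series held a single number and no pair, so nothing showed whether the configuration at this position counted for growth inhibition; this one pair now shows no difference that can be told apart from repeat measurements. The comparison isolates this single stereocentre, with nothing else in the structures available to blur the reading: the fact that compounds 2 and 3 differ only in the configuration as drawn

One pair at one position cannot show whether the same holds elsewhere in the series, and compound 1, with no result reported, adds no second reading. The compounds shown also leave open whether this stereocentre would remain as silent in a compound carrying a free hydroxyl group or an amine on the shared core, since every number here comes from compounds that share the same groups apart from this one configuration.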